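The compounds below may be only part of what the source reports. "The series", "measured", "known", "first", "only" and "open" are said of these compounds alone.

Working notes on the series.

Compound 1 `COc1ccc(-n2ccc(=O)c(C(=O)Nc3ccc(Oc4ccnc5[nH]ccc45)cc3)n2)cc1` carries a methoxy group on the phenyl attached to the pyridazinone, and in a functional assay on A549 cells (Homo sapiens) for cytotoxicity, read by MTT assay, with a stated time of 72 h (on this read-out lower numbers stand for stronger inhibition and higher numbers for weaker inhibition), compound 1 gives 53100 nM. Compound 2 `O=C(Nc1ccc(Oc2ccnc3[nH]ccc23)cc1)c1nn(-c2ccc(Br)cc2)ccc1=O` differs from it by one change, (bromo in place of methoxy on an aromatic carbon), and in this assay compound 2 gives 6240 nM. For the measured compounds named here, the step of an 8.5-fold lower number from compound 1 to compound 2 (0.93 log units; beyond the scatter) is the only measured step in the set.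

Compound 3 `COc1ccc(-n2ccc(=O)c(C(=O)Nc3ccc(Oc4ccnc5c4ccn5C)c(F)c3)n2)cc1` has a different core; how the core of compound 3 differs from the core of compound 1 is not broken down here. In this assay compound 3 gives > 60000 nM, which is a limit of the assay and not a number, as noted in the limit of > 60000 nM in this assay, at which 1 of the 3 values shown sits.

Compound 4 `Cn1ccc2c(Oc3ccc(NC(=O)c4nn(-c5ccc(Br)cc5)ccc4=O)cc3F)ccnc21` is not yet measured. It differs from compound 3 by bromo in place of methoxy on an aromatic carbon, and the place description matches that of the change from compound 1 to compound 2 word for word, so this is the same change carried onto the core of compound 3. Whether it carries over is a single-pair question; only compound 1 and compound 2 speak to it.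

Expectation: the step of an at least 4.0-fold lower number from compound 3 to compound 4 (0.60 log units; beyond the scatter) in this assay is estimated to resemble an 8.5-fold lower number from compound 1 to compound 2 (0.93 log units; beyond the scatter), resting on compound 2 and its value 6240 nM against compound 1. Since compound 3 sits only at a limit, the starting point is uncertain and the estimate is wide. Compound 4 is expected to give about 15000 nM in this assay, within 5000 nM to 60000 nM.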

Compound 4, half-maximal inhibitory concentration: > 60000 nM
Compound 4 was reported as a limit; the forecaster's own chance of this, stated with the estimate: 25%; middle value at least 4.0-fold (0.60 log units) from the limit.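

In this assay compound 3 gives > 60000 nM, a limit of the assay and not a number. Compound 4 gives > 60000 nM, also a limit, so no step can be read between compound 3 and compound 4: the limit of > 60000 nM in this assay, at which 2 of the 4 values shown sit.

The compounds shown leave open whether bromo in place of methoxy changes the value on the core of compound 3 as it does from compound 1 to compound 2.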